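The source may report more compounds than this note shows. Statements on the series, on what has been measured and on what is new or still open speak of the compounds shown alone.

Series notes. Compound 1 `N#Cc1ccc2nc(-c3cncnc3C(F)F)n(C3CC3)c2c1` and compound 2 `N#Cc1ccc2nc(-c3cncnc3C(F)(F)F)n(C3CC3)c2c1` share one core; compound 3 `N#Cc1ccc2nc(-c3cncnc3C(F)F)n(C3CC3)c2n1` and compound 4 `N#Cc1ccc2nc(-c3cncnc3C(F)(F)F)n(C3CC3)c2n1` share a second core, and the difference between the two cores is not broken down here. In an ADME assay on cells for inhibition of cytochrome P450 11B1, mitochondrial (Homo sapiens), read by HPLC, with a stated time of 60 min (on this read-out higher numbers stand for weaker inhibition and lower numbers for stronger inhibition), compound 1 gives 2040 nM and compound 2 gives 4170 nM. The change between them is fluoro in place of hydrogen on a saturated chain carbon bound to an aromatic carbon and two fluorine atoms, and it made a 2.0-fold higher number from compound 1 to compound 2 (0.31 log units; beyond the scatter). In this assay compound 3 gives 3930 nM; set against compound 2 the gap is within the scatter, and set against compound 1 it is also within the scatter, so nothing separates these three beyond the usual spread of repeat runs.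

Compound 4 has not yet been measured in this assay. It arises from compound 3 by fluoro in place of hydrogen on a saturated chain carbon bound to an aromatic carbon and two fluorine atoms, which is the same change as that made from compound 1 to compound 2, at a place described in the same words. Within the data shown here, only one prior example of the change exists in this set, and it sits on the other core, so the expectation rests on that single pair. The step to compound 4 is expected to be a 1.9-fold higher number from compound 3 to compound 4 (0.28 log units; within the scatter), because the same change earlier gave a 2.0-fold higher number from compound 1 to compound 2 (0.31 log units; beyond the scatter). Compound 4 is accordingly expected to give about 7500 nM in this assay. The range allowed for compound 4 is estimated as 3500 nM to 16000 nM, wide enough to cover one step repeated on a different core.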

Compound 4, half-maximal inhibitory concentration: 4810 nM
Beside the measured number, compound 4's estimate is 1.6-fold (0.19 log units) above it, within the range that was stated.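

Working from the core of compound 3 in this assay, replacing difluoromethyl with trifluoromethyl gives a 1.2-fold higher number from compound 3 to compound 4 (0.09 log units; within the scatter), so on this core the extra fluorine leaves no readable change. Set beside the earlier step, the two results cannot be told apart: the same change on two cores in this assay, a 2.0-fold higher number (0.31 log units; beyond the scatter) from compound 1 to compound 2 and a 1.2-fold higher number (0.09 log units; within the scatter) from compound 3 to compound 4, 1.7-fold (0.22 log units) apart, within the scatter of two such steps This supports only a modest statement: nothing in the two pairs indicates that the core alters the outcome of the change, and neither pair points to a stronger inhibition with trifluoromethyl, but two pairs, one of them within the usual spread of repeat runs, do not establish a constant step size that can be carried to a further core, nor do they show that the step on the core of compound 3 is a real one.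

As far as these compounds go, all four compounds carry either difluoromethyl or trifluoromethyl at this place, so it remains open how a methyl group, a bare hydrogen or a longer chain such as pentafluoroethyl would read out. From the compounds shown here alone, all four also share the nitrile, and whether the same change would keep its size with an amide or a carboxylic acid in that group's stead is equally open.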